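Swapping chloro for fluoro on compound 3

The source may hold more compounds than are shown below. What is called first, only, known or untested is meant among the compounds shown, and "the series" means these compounds.

compound 1 `C/C(=N\NC(=S)Nc1ccccc1I)c1ccccn1` gives 8.09 nM
compound 2 `C/C(=N/NC(=S)Nc1ccccc1F)c1ccccn1` gives 3.1 nM
compound 3 `C/C(=N\NC(=S)Nc1ccccc1Cl)c1ccccn1` gives 1.1 nM

In a functional assay on T98G cells (Homo sapiens) for cytotoxicity, read by MTT assay, with a stated time of 48 h (a higher number here means a weaker inhibitor, a lower number a stronger inhibitor), compound 3 has the lowest number of these three, which makes it the strongest inhibitor among them. The next candidate is compound 4 `C/C(=N\NC(=S)Nc1ccccc1F)c1ccccn1` and its change is small: fluoro in place of chloro on an aromatic carbon, ortho to a large group fluoro in place of chloro on an aromatic carbon with the rest of the structure kept.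

Within the data shown here, only one measured step exchanges one such group for another. Chloro in place of iodo gave a 7.4-fold lower number from compound 1 to compound 3 (0.87 log units; beyond the scatter) and that modest step shows that a swap of this kind can move the number beyond the scatter. It does not test fluoro, however. The closest guide is compound 2, which also carries fluoro and gives 3.1 nM in this assay so a small rise from compound 3 seems likely.

The expected step is a 2.3-fold higher number from compound 3 to compound 4 (0.36 log units; beyond the scatter) and it may prove hard to separate from the scatter. Compound 4 is estimated at 2.5 nM within a range of 0.9 nM to 7 nM in this assay for now.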

Compound 4, half-maximal inhibitory concentration: 3.1 nM
The estimate for compound 4 lay 1.2-fold (0.09 log units) below the measured number; low and high end bracket the measured number.
By their numbers in this assay, from the lowest: compound 3; then compounds 2 and 4 (each within the scatter of the next); then compound 1.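

In this assay, among these compounds, this is the first direct comparison of fluoro with chloro on this aromatic carbon, and the swap gives a 2.8-fold higher number from compound 3 to compound 4 (0.45 log units; beyond the scatter) while fluoro in place of iodo gives a 2.6-fold lower number from compound 1 to compound 4 (0.42 log units; beyond the scatter). With the double bond drawn the same way, chloro therefore has the lowest number of the three groups at this place, with fluoro in the middle and iodo highest. How the double bond is drawn makes no visible difference here, with no change at the digits printed from compound 2 to compound 4 (within the scatter) as the result of an unusually clean comparison: the fact that compounds 2 and 4 differ only in the configuration as drawn.

The compounds shown leave open how a group that is not a halogen, such as an amine or a methoxy, would behave on this carbon. They also leave open whether chloro and iodo would match their present numbers with the double bond drawn the other way, as only fluoro appears in both forms.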